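The source may hold more compounds than are shown below. What is called first, only, known or untested is meant among the compounds shown, and "the series" means these compounds.

In a functional assay on HL-60 cells (Homo sapiens) for inhibition, read by CCK-8 assay, with a stated time of 48 h (on this read-out lower numbers stand for stronger inhibition and higher numbers for weaker inhibition), compound 1 (`Cc1ccc(-c2ccsc2S(=O)(=O)NCCNC(=O)Nc2cc(C(F)(F)F)cc(C(F)(F)F)c2)c(Oc2ccc(O)c(O)c2)c1`) gives 3700 nM and compound 2 (`COc1cccc(NC(=O)NCCNS(=O)(=O)c2ccc(-c3ccccc3OCc3ccccc3)s2)c1`) gives 1700 nM as the lower of the two actual numbers, a gap beyond the scatter. Compound 3 (`COc1ccc(Oc2ccc([N+](=O)[O-])cc2-c2ccsc2S(=O)(=O)N2CCN(C(=S)Nc3ccc([N+](=O)[O-])cc3)CC2)cc1OC`) reads > 50000 nM here, which is a limit of the assay and not a number. Compound 4 (`O=S(=O)(NCCNC(=S)Nc1ccc(Cl)cc1)c1ccc(-c2ccccc2OCc2ccccc2)s1`) is not yet measured and departs from compound 2 in one place: a group of 10 heavy atoms (7 carbon, 1 nitrogen, 1 sulfur, 1 chlorine; one six-membered aromatic ring of carbon only) in place of a group of 11 heavy atoms (8 carbon, 1 nitrogen, 2 oxygen; one six-membered aromatic ring of carbon only), on an amine nitrogen. For the measured compounds named here, no measured pair shows this change, so in this assay the expected step stays within the scatter, leaning if anything towards a higher number. The estimated move is a 1.5-fold higher number from compound 2 to compound 4 (0.17 log units; within the scatter) and would be a small one. For compound 4 the expected value is 2500 nM, with an estimated range from 700 nM to 9000 nM.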

Compound 4, half-maximal inhibitory concentration: > 50000 nM
Compound 4 gave a limit, no number; the forecaster's own chance of this, stated with the estimate: 5%; middle value at least 20-fold (1.30 log units) from the limit.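

In this assay, for the compounds shown here, this is the first step read at the amine nitrogen, and it is large: an at least 29-fold higher number from compound 2 to compound 4 (1.46 log units; beyond the scatter). Compound 4 reads > 50000 nM, which is a limit and not a number. So the group on this nitrogen is not interchangeable here, even though the entering and leaving groups each hold one six-membered aromatic ring, and the size of the step stays open: the limit of > 50000 nM in this assay, at which 2 of the 4 values shown sit.

Sulfur and chlorine enter together, so the compounds shown leave open which of them goes with the step. They also leave open how a plain phenyl or a pyridine ring on this nitrogen would read.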